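A few compounds are considered here, and "the series" means these few. Any claim that something is new, unique, unknown or untested is made for them only; others in the source may bear on it.

Working notes on the series, all read in a functional assay on MIA PaCa-2 cells (Homo sapiens) for inhibition, read by MTT assay, with a stated time of 48 h, tested at 10 uM; a lower number here means less inhibition of growth, a higher number more inhibition of growth at the concentration tested. Compound 1 (`CCOC(=O)N1CCN(Cc2c(O)c([C@H]3CCN(C)C[C@H]3O)c3oc(C)cc(=O)c3c2O)CC1`) gives 4%, compound 2 (`Cc1cc(=O)c2c(O)c(CN3CCCC3C(=O)O)c(O)c([C@H]3CCN(C)C[C@H]3O)c2o1`) gives 10%, and compound 3 (`Cc1oc2c([C@H]3CCN(C)C[C@H]3O)c(O)cc(O)c2c(=O)c1C(O)c1ccccc1Br`) gives 10%. Among the measured compounds shown here, compound 3 is therefore level with compound 2 and within the scatter of compound 1, and no compound in this set separates from the others.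

The next entry is compound 4 (`Cc1oc2c([C@H]3CCN(C)C[C@H]3O)c(O)cc(O)c2c(=O)c1C(O)c1cc(F)cc(F)c1`). It carries 3,5-difluorophenyl in place of 2-bromophenyl on a saturated chain carbon bound to an aromatic carbon and an oxygen on a saturated carbon.

For the measured compounds named here, only one measured step is available, a number 6 percentage points higher from compound 1 to compound 2 (within the scatter). It concerns a different group and stays within the scatter, so it bears on this change only indirectly. It shows one substantial exchange of groups on the shared core with no measurable consequence here. Going by the values given here, no measured pair tests a change of the aryl group itself, which leaves the size of this step untested by direct comparison.

No shift beyond the scatter is therefore expected, and no direction can be assigned with any confidence. The estimated change is a number 2 percentage points higher from compound 3 to compound 4 (within the scatter). For compound 4 the expected value is 12%, with an estimated range of 2% to 30%.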

Compound 4, percent growth inhibition at one concentration: 6%
The estimate for compound 4 lay 6 percentage points above the measured number; measured number inside the range.
By their numbers in this assay, from the lowest: compounds 1, 4, 2 and 3 (each within the scatter of the next).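

Among the compounds shown here, the first measured exchange of the aryl group at this place, 3,5-difluorophenyl in place of 2-bromophenyl on a saturated chain carbon bound to an aromatic carbon and an oxygen on a saturated carbon, gives in this assay a number 4 percentage points lower from compound 3 to compound 4 (within the scatter), so a change in both the halogen and its place on the phenyl ring does not separate the two compounds. For the compounds shown here, this is the first direct comparison of aryl groups, and it adds a second substantial exchange of groups, at a different place from the one in the earlier step, that stays within the scatter. The data shown offer no explanation for this outcome.

From the compounds shown here alone, whether a phenyl ring carrying a methoxy group, a nitrile or an amine would behave like the two halogenated rings remains open, as does the replacement of the aryl group by a saturated ring such as cyclohexyl. Going by these compounds, with all numbers in the set within the scatter of one another, it also remains open whether any group at this place can give growth inhibition that stands clearly apart from these compounds.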